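A few compounds are considered here, and "the series" means these few. Any claim that something is new, unique, unknown or untested is made for them only; others in the source may bear on it.

Measured in a functional assay on the whole organism with Mus musculus as the target; on this read-out lower numbers stand for an effect already at smaller amounts and higher numbers for an effect only at larger amounts of compound:
Compound 1 `CCCCn1c(=O)[nH]c2c(ncn2C2O[C@H](CO)[C@@H](O)[C@H]2O)c1=N`: > 100 mg/kg, a limit
Compound 2 `Cn1c(=O)[nH]c2c(nc(Br)n2C2O[C@H](CO)[C@@H](O)[C@H]2O)c1=N`: > 100 mg/kg, a limit

Neither compound gives a number in this assay. The picture so far is the limit of > 100 mg/kg in this assay, at which 2 of the 2 values shown sit. Compound 2 stands at > 100 mg/kg, which is a limit of the assay and not a measured dose. Among the measured compounds shown here, its true position is therefore unknown, and no measured step connects the two compounds.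

The next compound, compound 3 `Cn1c(=O)[nH]c2c(nc(NN)n2C2O[C@H](CO)[C@@H](O)[C@H]2O)c1=N`, keeps the core and the sugar-bearing group of compound 2 and changes one place. Aminoamino replaces bromo on an aromatic carbon, between two ring nitrogen atoms (aminoamino in place of bromo on an aromatic carbon).

With only limits to go on, no step beyond the usual scatter is expected in this assay, and no direction can be favoured with confidence. This expectation rests on compound 2, whose reading is > 100 mg/kg. The expected change is a step that the limit leaves unreadable from compound 2 to compound 3. A report of only a limit is the likeliest outcome. Should a number emerge, the estimate for compound 3 is 130 mg/kg, with an expected range from 50 mg/kg to 400 mg/kg.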

Compound 3, dose for half-maximal effect: > 100 mg/kg
Compound 3 ended at the assay's limit (the forecaster's own chance of this, stated with the estimate: 70%); the middle value lies beyond the limit too.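

In this assay compound 3 gives > 100 mg/kg, which is a limit and not a number. Aminoamino in place of bromo therefore yields no readable step between compound 2 and compound 3, and the three compounds share one reading: the limit of > 100 mg/kg in this assay, at which 3 of the 3 values shown sit.

On these data alone, what dose each of the three compounds would need for half-maximal effect stays open.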